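A Longer Chain Ending in a Thioamide

The compounds below may be only part of what the source reports. "The series", "measured", "known", "first", "only" and "open" are said of these compounds alone.

The measured compounds:
compound 1, `N=C(S)CCn1nc(-c2cccs2)ccc1=O`: 50.2%
compound 2, `NC(=O)CCn1nc(-c2ccccc2)ccc1=O`: -2.8%
compound 3, `CC(CC(=N)S)n1nc(-c2ccccc2)ccc1=O`: 15.5%

All three were tested in a functional assay on the whole organism (stomach) for inhibition, with Rattus norvegicus as the target, at a dose of 100 mg/kg by the intraduodenal route; a lower number here means less inhibition, a higher number more inhibition at the dose given (going by the name of the read-out). Compound 2 gives the lowest of the three numbers; compound 3 stands nearest to it, and compound 1 lies furthest away. Among the measured compounds shown here, the one step that follows a single change, a number 18.3 percentage points higher from compound 2 to compound 3 (beyond the scatter), swaps the carbamoyl-bearing chain for a chain bearing a thioamide. Compound 1 also carries a thioamide, but it differs from compound 2 in more than one place, so its value shows only that a thioamide can go with the highest number seen here.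

Compound 4, `N=C(S)CCCCn1nc(-c2ccccc2)ccc1=O`, is the next compound to be measured in this assay. Its change from compound 2 is a group of 5 heavy atoms (3 carbon, 1 nitrogen, 1 sulfur; no ring) in place of a group of 3 heavy atoms (1 carbon, 1 nitrogen, 1 oxygen; no ring), on a saturated chain carbon, two bonds along the chain from an aromatic nitrogen. Since compound 2 rose to compound 3 on a comparable swap, and compound 1 sits higher still, a rise is expected, of about the size seen in that step, so that a number 22.8 percentage points higher from compound 2 to compound 4 (beyond the scatter) is the estimated change. Compound 4 is expected to give 20%, within a range from 0% to 45%.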

Compound 4, a percentage reported as inhibition, in the whole organism at one dose (the size of the read-out at that dose, not a potency): 33.8%
For compound 4 the middle estimate is 13.8 percentage points below the measured one, and the stated range covers the measured number.
By their numbers in this assay, from the lowest: compound 2; then compound 3; then compound 4; then compound 1.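

At this saturated chain carbon, two bonds along the chain from an aromatic nitrogen, the change in this assay gives a number 36.6 percentage points higher from compound 2 to compound 4 (beyond the scatter). This step is large, whereas the step to compound 3 from the same starting point is modest, so a sizeable rise in inhibition at this dose is possible on the core of compound 2 itself. No measurement shown here accounts for the rise.

The entering group differs from carbamoyl both in its number of heavy atoms and in carrying sulfur in place of oxygen, so the compounds shown cannot tell how much of the step belongs to each difference. Carbamoyl on the longer chain of compound 4, or a carboxylic acid at the end of that chain, would be the direct comparison still open.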